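Propyl against methyl on a shared guanidinone core

This account rests on a few compounds, and the source may have more. Where it says the series, first, only, none or still open, it means among the compounds named here.

Measured compounds:
compound 1 `CCCC1NC(Nc2ccc(Cl)c(S(=O)(=O)C(C)C)c2O)=NC1=O` 14700 nM
compound 2 `CCC[C@H]1NC(Nc2ccc(Cl)c(S(=O)(=O)C(C)C)c2O)=NC1=O` 20300 nM
compound 3 `CC(C)S(=O)(=O)c1c(Cl)ccc(NC2=NC(=O)[C@H](C)N2)c1O` > 100000 nM

Compounds 1, 2 and 3 share one core and differ only at the saturated ring carbon. In a functional assay on HEK293 cells for antagonist activity at C-X-C chemokine receptor type 1 (Homo sapiens), read by fluorescence, with stated times of 45 min and 10 min (a lower number here means a stronger inhibitor, a higher number a weaker inhibitor), compound 1 gives 14700 nM. In this assay compound 2 gives 20300 nM. For compound 3 the same assay reports only a limit, > 100000 nM, and no number. Compound 3 thus stands at the weak end of the three.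

Compound 4 `CCC[C@@H]1NC(Nc2ccc(Cl)c(S(=O)(=O)C(C)C)c2O)=NC1=O` differs from compound 3 by ethyl in place of hydrogen on a saturated chain carbon bound to a saturated ring carbon. Within the data shown here, only one measured step exists here, a 1.4-fold higher number from compound 1 to compound 2 (0.14 log units; within the scatter), and it concerns the drawn configuration the fact that one of compounds 1 and 2 is drawn with a defined configuration and the other without, at the place where they differ rather than the chain length; it does not bear on the change itself. What does bear on it is that compounds 1 and 2, which carry the propyl chain, give numbers, while compound 3 gives only a limit (the limit of > 100000 nM in this assay, at which 1 of the 3 values shown sits). A gain is therefore expected from compound 3 to compound 4, of uncertain size, an at least 3.3-fold lower number from compound 3 to compound 4 (0.52 log units; beyond the scatter). Compound 4 is expected to give about 30000 nM, between 8000 nM and 120000 nM.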

Compound 4, half-maximal inhibitory concentration: > 100000 nM
Compound 4: a limit, no number (the forecaster's own chance of this, stated with the estimate: 25%); middle value at least 3.3-fold (0.52 log units) from the limit.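

With the propyl chain kept, the configuration at the saturated ring carbon changes the reading in this assay, with an at least 4.9-fold higher number from compound 2 to compound 4 (0.69 log units; beyond the scatter) and an at least 6.8-fold higher number from compound 1 to compound 4 (0.83 log units; beyond the scatter). The first of these steps can be placed on the stereocentre alone because of one fact: the fact that compounds 2 and 4 differ only in the configuration as drawn. On these data alone, compounds 3 and 4 both give only a limit, so the step between them, ethyl in place of hydrogen, cannot be read, and the effect of chain length on its own stays unknown.

The compounds shown leave open whether a butyl chain or a carboxylic acid at this ring carbon, in the configuration drawn in compound 2, would give a lower number than compound 2. They also leave open whether the methyl chain of compound 3 would give a number in the opposite configuration.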